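Nitro for Fluoro on the Benzyl Ring: Cytotoxicity Outlook

This account rests on a few compounds, and the source may have more. Where it says the series, first, only, none or still open, it means among the compounds named here.

Compound 1 `COc1ccc(Cn2cc(CNC(=O)c3ccc([N+](=O)[O-])o3)nn2)cc1F` gives 312000 nM in an ADME assay on Vero cells (Chlorocebus sabaeus) for cytotoxicity (a lower number here means a stronger inhibitor, a higher number a weaker inhibitor), the highest of the three numbers shown. Compound 2 `O=C(NCc1cn(Cc2ccc([N+](=O)[O-])cc2)nn1)c1ccc([N+](=O)[O-])o1` gives 291000 nM and compound 3 `COc1cc(Cn2cc(CNC(=O)c3ccc([N+](=O)[O-])o3)nn2)ccc1F` gives 225000 nM; the steps of a 1.1-fold lower number from compound 1 to compound 2 (0.03 log units; within the scatter) and a 1.4-fold lower number from compound 1 to compound 3 (0.14 log units; within the scatter) both stay within the scatter, so the three lie together. Compound 4 `COc1ccc(Cn2cc(CNC(=O)c3ccc([N+](=O)[O-])o3)nn2)cc1[N+](=O)[O-]` arises from compound 1 by nitro in place of fluoro on an aromatic carbon. Among the compounds with values here, the nearest precedent is the step in which a nitro-bearing ring replaced the fluoro-methoxy ring, a 1.1-fold lower number from compound 1 to compound 2 (0.03 log units; within the scatter), which stayed within the scatter, and the step with rearranged fluoro and methoxy groups, a 1.4-fold lower number from compound 1 to compound 3 (0.14 log units; within the scatter), was likewise flat. Compound 4 is therefore expected to show no step beyond the scatter, a 1.0-fold lower number from compound 1 to compound 4 (0.02 log units; within the scatter). The estimate for compound 4 in this assay is 300000 nM, with a range from 150000 nM to 600000 nM.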

Compound 4, half-maximal inhibitory concentration: 176000 nM
The estimate for compound 4 lay 1.7-fold (0.23 log units) above the measured number, and the stated range covers the measured number.
By their numbers in this assay, from the lowest: compounds 4, 3, 2 and 1 (each within the scatter of the next).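

In this assay, exchanging fluoro for nitro on this aromatic carbon, ortho to a methoxy group, gives a 1.8-fold lower number from compound 1 to compound 4 (0.25 log units; within the scatter) and stays within the scatter, although 3 heavy atoms and 2 hydrogen-bond acceptors enter. Unlike the earlier steps, which replaced the whole substituted ring, this one changes a single group and keeps the methoxy group and the rest of compound 1. No measurement bearing on the reason for this result is available. The compounds shown leave open whether an amine or a carboxylic acid on this carbon would also stay within the scatter, and whether a longer chain in place of the methoxy group would.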